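This account rests on a few compounds, and the source may have more. Where it says the series, first, only, none or still open, it means among the compounds named here.

Measured compounds:
- Compound 1, `CSc1nc2c(N)ncnc2n1[C@@H]1O[C@H](COP(=O)(O)OP(=O)(O)OP(=O)(O)O)[C@@H](O)[C@H]1O` — in an assay (strain Sprague-Dawley) for inhibition of GTP:AMP phosphotransferase AK3, mitochondrial (Rattus norvegicus), using Lineweaver-Burk analysis (on this read-out higher numbers stand for weaker inhibition and lower numbers for stronger inhibition), compound 1 gives 360000 nM
- Compound 2, `CCCSc1nc2c(N)ncnc2n1[C@@H]1O[C@H](COP(=O)(O)OP(=O)(O)OP(=O)(O)O)[C@@H](O)[C@H]1O` — in this assay compound 2 gives 65000 nM

For the measured compounds named here, compound 1 stands at the highest of the two numbers measured so far; its nearest neighbour is compound 2, reached by a 5.5-fold lower number from compound 1 to compound 2 (0.74 log units; beyond the scatter), a step described as modest but beyond the scatter. That step put ethyl in place of hydrogen on a saturated chain carbon bound to a sulfur, so a larger group on the sulfur went with a lower number.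

Compound 3, `Nc1ncnc2c1nc(Sc1ccccc1)n2[C@@H]1O[C@H](COP(=O)(O)OP(=O)(O)OP(=O)(O)O)[C@@H](O)[C@H]1O`, differs from compound 1 by phenyl in place of methyl on a sulfur. Going by the values given here, only the step from compound 1 to compound 2 bears on this change, and it shows that growing the group on the sulfur lowered the number in this assay. A phenyl is a larger addition than the ethyl of that step, but nothing measured here tells whether an aromatic ring on the sulfur behaves like a longer chain. The direction of the expectation is therefore a lower number, with a size estimated near the measured step, a 7.2-fold lower number from compound 1 to compound 3 (0.86 log units; beyond the scatter). For compound 3 the expected value in this assay is 50000 nM, within a range from 12000 nM to 200000 nM.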

Compound 3, inhibition constant: 320000 nM
For compound 3 the middle estimate is 6.4-fold (0.81 log units) below the measured one, and the stated range ends below it.
By their numbers in this assay, from the lowest: compound 2; then compounds 3 and 1 (each within the scatter of the next).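

In this assay the change from methyl to phenyl on the sulfur gives a 1.1-fold lower number from compound 1 to compound 3 (0.05 log units; within the scatter) and so does not bring the shift seen with propyl in compound 2. Placing phenyl on the sulfur in place of propyl gives a 4.9-fold higher number from compound 2 to compound 3 (0.69 log units; beyond the scatter) and leaves compound 2 with the lowest number of the three, beyond the scatter of both other compounds. The link between a larger group on the sulfur and a lower number therefore rests on compound 2 alone, and compound 3 goes against it.

Nothing at hand gives a reason for this difference between the propyl chain and the phenyl ring.

The three compounds leave open whether a longer chain, such as butyl or hexyl, would lower the number further than propyl does. They also leave open whether a benzyl or cyclohexyl group on the sulfur would fall with propyl or with phenyl, and whether a substituted phenyl, such as 4-chlorophenyl or 4-aminophenyl, would differ from phenyl itself.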